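Replacing 3-nitrophenyl with 3,5-dichlorophenyl in the series

This account rests on a few compounds, and the source may have more. Where it says the series, first, only, none or still open, it means among the compounds named here.

In a functional assay (aorta) for inhibition, with Rattus norvegicus as the target, with a stated time of 8 days (on this read-out lower numbers stand for stronger inhibition and higher numbers for weaker inhibition), compound 3 (`Cc1nsc(-c2ccc(N3CCN(c4cccc([N+](=O)[O-])c4)CC3)nn2)n1`) gives 3 nM as its value. This lies within the scatter of compound 1 (`Cc1nsc(-c2ccc(N3CCN(c4cccc(C(F)(F)F)c4)CC3)nc2)n1`), which gives 5 nM on the same read-out. Going by the values given here, compound 2 (`Cc1nsc(-c2ccc(N3CCN(c4cccc(C(F)(F)F)c4)CC3)nn2)n1`) gives 0.3 nM and is the only number clearly apart from compound 3.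

The next structure, compound 4 (`Cc1nsc(-c2ccc(N3CCN(c4cc(Cl)cc(Cl)c4)CC3)nn2)n1`), has 3,5-dichlorophenyl in place of 3-nitrophenyl on an amine nitrogen in a ring.

Among the compounds with values here, one measured step bears on this group: nitro in place of trifluoromethyl on an aromatic carbon, a 10-fold higher number from compound 2 to compound 3 (1.00 log units; beyond the scatter), a modest change. Within the data shown here, no measured compound carries chlorine, so this step is only an indirect guide, and the trifluoromethyl compound 2 at 0.3 nM shows that numbers below that of compound 3 are reachable here.

A modest move to a lower number is expected, a 3.0-fold lower number from compound 3 to compound 4 (0.48 log units; beyond the scatter), though no change beyond the scatter would also fit. Compound 4 is estimated at 1 nM in this assay, with an expected range of 0.2 nM to 5 nM for the measurement.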

Compound 4, half-maximal inhibitory concentration: < 0.1 nM
Compound 4: only a limit was reported; the forecaster's own chance of this, stated with the estimate: 2%; middle value at least 10-fold (1.00 log units) from the limit.
By their numbers in this assay, from the lowest: compound 2; then compounds 3 and 1 (each within the scatter of the next). At a limit, below all of these: compound 4.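

On the amine nitrogen in the ring, 3,5-dichlorophenyl in place of 3-nitrophenyl gives an at least 30-fold lower number from compound 3 to compound 4 (1.47 log units; beyond the scatter), a large step, whereas the earlier change on this aromatic group, a 10-fold higher number from compound 2 to compound 3 (1.00 log units; beyond the scatter), was modest. Going by these compounds alone, this position can therefore move the number further than the earlier compounds showed. In this assay, compound 4 has only a limit, < 0.1 nM, so the full size of the step cannot be read: the limit of < 0.1 nM in this assay, at which 1 of the 4 values shown sits.

The compounds shown leave open whether a single chlorine on this phenyl ring would give a similar step, or whether both chlorines are needed. From the compounds shown here alone, how a methoxy or an amine at this place would read also stays open, as does whether 3,5-dichlorophenyl would give a similar step on the core of compound 1.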